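The source may hold more compounds than are shown below. What is called first, only, known or untested is meant among the compounds shown, and "the series" means these compounds.

Compound 1 `CC1CCC(=O)N1CC#CCn1ccnc1` is the reference point of the series; in a functional assay on the whole organism for antagonist activity, with Mus musculus as the target (on this read-out higher numbers stand for an effect only at larger amounts of compound and lower numbers for an effect already at smaller amounts), compound 1 gives 0.54 mg/kg. Compound 2 `CC1CCC(=O)N1CC#CCN(C)C` differs only by dimethylamino in place of 1H-imidazol-1-yl on a saturated chain carbon bound to a triple-bonded carbon, and in this assay compound 2 gives > 100 mg/kg, which is a limit of the assay and not a number. That change therefore produced an at least 180-fold higher number from compound 1 to compound 2 (2.26 log units; beyond the scatter). Compound 3 `COC(=O)N(C)C(C)C#CCn1ccnc1` carries a different core; how its core differs from that of compound 1 is not broken down here. In this assay compound 3 gives > 100 mg/kg, again a limit rather than a number. Compound 4 `COC(=O)N(C)C(C)C#CCN(C)C` is not yet measured and arises from compound 3 by dimethylamino in place of 1H-imidazol-1-yl on a saturated chain carbon bound to a triple-bonded carbon, the same change as between compound 1 and compound 2. Because compound 3 already sits at the limit of > 100 mg/kg in this assay, at which 2 of the 3 values shown sit, and the earlier step carried compound 2 to that same limit, the step that the limit leaves unreadable from compound 3 to compound 4 is expected to be flat or to worsen further. Compound 4 is estimated at 300 mg/kg, most probably reported once more as a limit.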

Compound 4, dose for half-maximal effect: > 100 mg/kg
Compound 4: no number, only a limit; the forecaster's own chance of this, stated with the estimate: 90%; the middle value lies beyond the limit too.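

The step from compound 3 to compound 4 cannot be read: both compounds stand at a limit of this assay, not at a number. The compounds shown leave open how far past that limit either compound lies, and whether dimethylamino in place of 1H-imidazol-1-yl changes anything on the core of compound 3.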